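Opening a pyrrolidine ring: from compound 2 to compound 3

The compounds below may be only part of what the source reports. "The series", "measured", "known", "first", "only" and "open" are said of these compounds alone.

Measured so far:
compound 1 `CC(C)C[C@@H](N)C(=O)Nc1cc2cc[nH]c(=O)c2cc1Cl`, 19 nM
compound 2 `O=C(Nc1cc2cc[nH]c(=O)c2cc1Cl)[C@H]1CCCN1`, 130 nM

In an assay on isolated protein for inhibition of Rho-associated protein kinase 2 (Homo sapiens) (a lower number here means a stronger inhibitor, a higher number a weaker inhibitor), compound 1 gives 19 nM. Compound 2 carries a pyrrolidin-2-yl group on the carbonyl carbon instead, and in this assay compound 2 gives 130 nM, the higher of the two numbers; the step of a 6.8-fold higher number from compound 1 to compound 2 (0.84 log units; beyond the scatter) lies beyond the scatter. Compound 3 `CC(C)[C@@H](N)C(=O)Nc1cc2cc[nH]c(=O)c2cc1Cl` differs from compound 2 by 1-amino-2-methylpropyl in place of pyrrolidin-2-yl on a carbonyl carbon. This change reopens the ring and returns to an open-chain group with a free amino group, much like compound 1, only with a shorter branched chain. Among the measured compounds shown here, the one step that bears on it, a 6.8-fold higher number from compound 1 to compound 2 (0.84 log units; beyond the scatter), suggests that undoing the ring closure should lower the number again, so a step of a 4.3-fold lower number from compound 2 to compound 3 (0.64 log units; beyond the scatter) is expected. On that basis compound 3 is estimated at 30 nM, with a likely range from 10 nM to 100 nM.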

Compound 3, half-maximal inhibitory concentration: 240 nM
For compound 3 the middle estimate is 8.0-fold (0.90 log units) below the measured one; the whole stated range lies below it.
By their numbers in this assay, from the lowest: compound 1; then compounds 2 and 3 (each within the scatter of the next).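

Opening the ring does not by itself bring the number back down: in this assay, swapping pyrrolidin-2-yl for 1-amino-2-methylpropyl gives (a 1.8-fold higher number from compound 2 to compound 3 (0.27 log units; within the scatter)), so the ring form and this open-chain form cannot be told apart here. The large change lies instead in the open chain itself, where isopropyl in place of isobutyl gives (a 13-fold higher number from compound 1 to compound 3 (1.10 log units; beyond the scatter)), which shows that a free amino group on an open chain is not enough and that the side chain on that carbon counts for much in this assay. Nothing available here explains either step.

The compounds shown leave open whether a longer chain than isobutyl, or a benzyl group, at this place would lower the number further or raise it. They also leave open what a hydroxyl group in place of the amine would do.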